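This account rests on a few compounds, and the source may have more. Where it says the series, first, only, none or still open, it means among the compounds named here.

Notes on the series in a functional assay on K562 cells (Homo sapiens) for cytotoxicity, read by MTT assay, with a stated time of 72 h; a lower number here means a stronger inhibitor, a higher number a weaker inhibitor. Compound 1 `COc1ccc(C(=O)O[C@H]2C=C(C)C(=O)C[C@@]3(C)CC[C@@](O)(C(C)C)[C@H]23)cc1` carries a methoxy-substituted benzoate ester on the shared core; in this assay compound 1 gives only a limit, > 100000 nM. Compound 3 `COc1ccc(C(=O)O[C@H]2CC(C)=C[C@@H](OC(C)=O)[C@@]3(C)[C@@H](OC(C)=O)C[C@@](O)(C(C)C)[C@H]23)cc1` carries the same ester together with two acetate groups; in this assay compound 3 likewise reaches only a limit, > 100000 nM. Within the data shown here, compound 2 `CC1=CC[C@]2(C)[C@@H]([C@@H](OC(=O)c3ccc(O)cc3)C1)[C@](O)(C(C)C)C[C@@H]2O` bears a hydroxy-substituted benzoate and is the one member with a numerical value; in this assay compound 2 gives 95000 nM. Among the measured compounds shown here, the two other values sit at the limit of > 100000 nM in this assay, at which 2 of the 3 values shown sit, so compound 2 stands as the single measured number among limits.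

Compound 4 `CC1=CC[C@@]2(C)CC[C@@](O)(C(C)C)[C@@H]2[C@@H](OC(=O)c2ccc(O)cc2)C1` differs from compound 2 by hydrogen in place of hydroxy on a saturated ring carbon. For the measured compounds named here, no pair of measured compounds differs in a single place, so no measured step anchors this change. With all three values shown at or near the limit, only a small change is expected. The step that this expectation means is estimated as a 1.2-fold higher number from compound 2 to compound 4 (0.06 log units; within the scatter), which would lie within the scatter. Compound 4 is expected at 110000 nM, in the range 50000 nM to 250000 nM, with a fair chance that only a limit is reported.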

Compound 4, half-maximal inhibitory concentration: > 100000 nM
Compound 4: no number, only a limit; the forecaster's own chance of this, stated with the estimate: 55%; the middle value does not contradict the limit.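

In this assay compound 4 gives only a limit, > 100000 nM. Among these compounds, replacing hydroxy with hydrogen on this saturated ring carbon provides the first single-place step, an at least 1.0-fold higher number from compound 2 to compound 4 (0.02 log units; that floor lies within the scatter), so the step has only a floor and does not show that removing the hydroxy group changes the read-out. Compound 2 remains the only compound with a numerical value, and the series now lies mostly at the limit: the limit of > 100000 nM in this assay, at which 3 of the 4 values shown sit.

Going by these compounds, how far the number would move with hydrogen in place of hydroxy remains open, since a step from a limit gives no upper size. Also open, on these data alone, is whether an amine, a carboxylic acid or a longer chain on this ring carbon would give a value clearly beyond the scatter from compound 2.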